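This account rests on a few compounds, and the source may have more. Where it says the series, first, only, none or still open, it means among the compounds named here.

Measured so far:
compound 1 `Cc1cc(O)cc(-c2nn(CC#N)cc2-c2ccnc(-c3ccc(Oc4ccccc4)cc3)c2)c1` gives -88%
compound 2 `COc1cc(C)cc(-c2nn(CC#N)cc2-c2ccnc(-c3ccc(N(C)C)cc3)c2)c1` gives -63%

In a functional assay on MDA-MB-468 cells (Homo sapiens) for cytotoxicity, read by sulforhodamine B assay, with a stated time of 48 h, tested at 10 uM (on this read-out higher numbers stand for a weaker effect at the one concentration tested and lower numbers for a stronger effect), compound 2 stands highest of the two numbers, and its nearest neighbour, compound 1, lies a step lower that is beyond the scatter. Compound 2 and compound 1 differ in two places, so their gap alone does not tell what either change does.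

Compound 3 `Cc1cc(O)cc(-c2nn(CC#N)cc2-c2ccnc(-c3ccc(N(C)C)cc3)c2)c1` is not yet measured. It differs from compound 2 by hydrogen in place of methyl on an oxygen on an aromatic ring. Among the measured compounds shown here, no step between measured compounds isolates this change, so the expected step of a number 7 percentage points lower from compound 2 to compound 3 (within the scatter) is small, likely within the scatter or modestly downward. Compound 3 is estimated at -70%, ranging from -95% to -40%.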

Compound 3, a percentage reported as activity, at one concentration (the size of the read-out at that concentration, not a potency): -61%
Compound 3: middle estimate off by 9 percentage points, on the low side, and the stated range covers the measured number.
By their numbers in this assay, from the lowest: compound 1; then compounds 2 and 3 (each within the scatter of the next).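

In this assay, the step for hydroxy in place of methoxy on this aromatic ring is a number 2 percentage points higher from compound 2 to compound 3 (within the scatter), so the two groups cannot be told apart at this position. With the hydroxy held fixed, dimethylamino in place of phenoxy gives a number 27 percentage points higher from compound 1 to compound 3 (beyond the scatter), which ties that gap to this one place on the shared core. Nothing available explains either step.

From the compounds shown here alone, whether an amine or a longer chain such as ethoxy at this position would read the same remains open. So does whether the phenoxy to dimethylamino step would hold with methoxy in place of hydroxy.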